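Notes on a macrocyclic ring series, compound 3 to compound 4

This account rests on a few compounds, and the source may have more. Where it says the series, first, only, none or still open, it means among the compounds named here.

Activity here is read in a functional assay on SW480 cells (Homo sapiens) for antiproliferative activity, read by MTT assay, with a stated time of 48 h; a lower number here means a stronger inhibitor, a higher number a weaker inhibitor. Compound 1 `CC(=O)OC/C1=C/C[C@](C)(CCC=C(C)C)/C=C/[C@@H](OC(=O)C=C(C)C)[C@](C)(OC(C)=O)/C=C/C1=O` gives 3520 nM, and compound 2 `COC/C1=C/C[C@](C)(CCC=C(C)C)/C=C/[C@@H](OC(=O)C=C(C)C)[C@](C)(OC)/C=C/C1=O` gives 14600 nM. Compound 3 `CC(C)=CCC[C@]1(C)/C=C/[C@@H](OC(=O)C=C(C)C)[C@](C)(O)/C=C/C(=O)/C(C(=O)O)=C\C1` is recorded only as a limit, > 10000 nM, not as a number. From the compounds shown here alone, it stands at the limit of > 10000 nM in this assay, at which 1 of the 3 values shown sits, so its true value is unknown beyond that bound.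

Compound 4 `COCOC/C1=C/C[C@](C)(CCC=C(C)C)/C=C/[C@@H](OC(=O)C=C(C)C)[C@](C)(O)/C=C/C1=O` has not yet been measured. It differs from compound 3 by (methoxymethoxy)methyl in place of carboxy on a double-bonded ring carbon, with the rest of the structure unchanged. For the measured compounds named here, no step between measured compounds covers this change, so the size of the move in this assay is open. The step from compound 3 to compound 4 is expected to be a moderate one toward a lower number, an at least 1.6-fold lower number from compound 3 to compound 4 (0.22 log units; that floor lies within the scatter). Compound 4 is estimated at 6000 nM, within a range from 2000 nM to 20000 nM.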

Compound 4, half-maximal inhibitory concentration: 3710 nM
Compound 4: middle estimate off by 1.6-fold (0.21 log units), on the high side; the measured number falls inside the stated range.
By their numbers in this assay, from the lowest: compounds 1 and 4 (each within the scatter of the next); then compound 2.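

In this assay, replacing carboxy with (methoxymethoxy)methyl on the double-bonded ring carbon gives an at least 2.6-fold lower number from compound 3 to compound 4 (0.43 log units; beyond the scatter), the first step read at this position. This shows that the position accepts a change of group with a move toward a lower number, and that carboxy is not needed there for a measured value in this assay. The step is a floor and not a full size: the limit of > 10000 nM in this assay, at which 1 of the 4 values shown sits.

The compounds shown leave open whether the move comes from the loss of carboxy or from the entering chain itself. A hydroxymethyl group or an amine at this carbon would help separate the two.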